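The source may hold more compounds than are shown below. What is called first, only, known or untested is meant among the compounds shown, and "the series" means these compounds.

Measured in a functional assay on MV4-11 cells (Homo sapiens) for antiproliferative activity, read by luminescence and CellTiter-Glo, with a stated time of 72 h; on this read-out lower numbers stand for stronger inhibition and higher numbers for weaker inhibition:
- Compound 1 `Cc1noc(C)c1-c1ccc2c(Nc3ccc(F)cc3)nn(C3CCCCO3)c2c1`: 9900 nM
- Compound 2 `Cc1ccc(Cn2nc(Nc3ccc(F)cc3)c3ccc(-c4c(C)noc4C)cc32)cc1`: "not determined" (no result reported)

Compound 2 thus has no number to stand on, and the only figure available is that of compound 1 at 9900 nM. Compound 3 `Cc1ccc(Cn2nc(Nc3ccc(C#N)cc3)c3ccc(-c4c(C)noc4C)cc32)cc1` has yet to be tested in this assay. The structural change is cyano in place of fluoro on an aromatic carbon, para to a large group. With no value for compound 2, the step cannot be sized from the data, and no shift beyond the usual scatter is expected in this assay in either direction. For compound 3 the expected value is 3000 nM, with an estimated range of 400 nM to 15000 nM.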

Compound 3, half-maximal inhibitory concentration: 5800 nM
Compound 3: middle estimate off by 1.9-fold (0.29 log units), on the low side; low and high end bracket the measured number.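

In this assay, within the data shown here, compound 3 gives 5800 nM but compound 2 has no number, so no step between compound 2 and compound 3 can be read. Going by these compounds, what the change from fluoro to cyano does to the read-out stays open. No evidence bears on this result.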